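Compound 3 loses its isobutyl group in compound 4

This account rests on a few compounds, and the source may have more. Where it says the series, first, only, none or still open, it means among the compounds named here.

Compound 1 `Cc1ccccc1-c1nc(CN2CCC(C(=O)NCCCN3CCCCC3)CC2)c(C)o1`: 18100 nM
Compound 2 `Cc1ccccc1-c1nc(CN2CCC(C(=O)NCCCN3[C@H](C)CCC[C@@H]3C)CC2)c(C)o1`: 21300 nM
Compound 3 `Cc1ccccc1-c1nc(CN2CCC(C(=O)NCCCN3CCCC(CC(C)C)C3)CC2)c(C)o1`: 4640 nM

In an ADME assay on Huh7.5.1 cells (Homo sapiens) for cytotoxicity, read by ATP content, with a stated time of 48 h (on this read-out lower numbers stand for higher toxicity in this test and higher numbers for lower toxicity in this test), compound 3 gives 4640 nM, the lowest of the three numbers and beyond the scatter from both of the others. Compound 4 `CCCN(CCC)CCNC(=O)C1CCN(Cc2nc(-c3ccccc3C)oc2C)CC1` has not yet been measured. The change is a group of 7 heavy atoms (6 carbon, 1 nitrogen; no ring) in place of a group of 11 heavy atoms (10 carbon, 1 nitrogen; one six-membered non-aromatic ring with 1 hetero atom), on a saturated chain carbon, two bonds along the chain from an amide-type nitrogen, so dipropylamino enters and the isobutyl-bearing ring leaves.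

Going by the values given here, three measured steps bear on this. Putting isobutyl in place of hydrogen on the ring gave a 3.9-fold lower number from compound 1 to compound 3 (0.59 log units; beyond the scatter), a modest step. The step of a 4.6-fold lower number from compound 2 to compound 3 (0.66 log units; beyond the scatter) is similar in size. Swapping one ring group for the other without isobutyl gave only a 1.2-fold higher number from compound 1 to compound 2 (0.07 log units; within the scatter), which is within the scatter. Compound 4, like compound 1 and compound 2, carries no isobutyl group, so a modest rise is expected in this assay. Among the compounds with values here, no measured compound carries dipropylamino, so the range stays wide.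

The expected change is a 3.2-fold higher number from compound 3 to compound 4 (0.51 log units; beyond the scatter).

Compound 4 is estimated at 15000 nM, with an expected range of 7000 nM to 32000 nM.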

Compound 4, half-maximal cytotoxic concentration: 30500 nM
For compound 4 the middle estimate is 2.0-fold (0.31 log units) below the measured one, within the range that was stated.
By their numbers in this assay, from the lowest: compound 3; then compounds 1, 2 and 4 (each within the scatter of the next).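

In this assay, dipropylamino, which has no ring, gives a result that cannot be told apart from those of the two ring-bearing amines: a 1.4-fold higher number from compound 2 to compound 4 (0.16 log units; within the scatter) and a 1.7-fold higher number from compound 1 to compound 4 (0.23 log units; within the scatter). Replacing (piperidin-1-yl)methyl or (2,6-dimethylpiperidin-1-yl)methyl with dipropylamino at this position therefore shows no change beyond the scatter, while compound 3, the only one of the four with an isobutyl group, stands apart, with a 6.6-fold higher number from compound 3 to compound 4 (0.82 log units; beyond the scatter). Nothing measured here explains that difference.

The compounds shown leave open whether the lower number belongs to isobutyl specifically or would also appear with another group on the same ring, such as propyl or cyclohexylmethyl. They also leave open how dibutylamino or morpholin-4-yl, or dipropylamino on a longer chain, would read in this test.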